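Shifting the acid and capping the phenol on a biaryl scaffold

The source may report more compounds than this note shows. Statements on the series, on what has been measured and on what is new or still open speak of the compounds shown alone.

Compound 1 `O=C(O)c1cc(-c2cccc(COc3ccc4c(c3)CN(C3CCCC3)C4=O)c2)ccc1O` carries a 3-carboxy-4-hydroxyphenyl group and, in an in vivo ADME assay on the whole organism for metabolic stability, with Rattus norvegicus as the target, at a dose of 10 mg/kg by the oral route (a higher number here means that the compound lasts longer, a lower number that the compound disappears faster), compound 1 gives 10.6 h. Compound 2 `O=C(O)c1cc(-c2cccc(COc3ccc4c(=O)n(C5CC5)sc4c3)c2)ccc1Cl`, built on a different core, gives 8.6 h. Compound 1 holds the larger of these two numbers, yet the gap to compound 2 lies within the usual scatter. Compound 3 `COc1ccc(C(=O)O)cc1-c1cccc(COc2ccc3c(c2)CN(C2CCCC2)C3=O)c1` differs from compound 1 by 5-carboxy-2-methoxyphenyl in place of 3-carboxy-4-hydroxyphenyl on an aromatic carbon. Among the measured compounds shown here, no measured pair shows such a change, so only a modest move is expected, slightly downward, from compound 1 to compound 3 in this assay; the step of a 1.3-fold lower number from compound 1 to compound 3 (0.12 log units; within the scatter) is estimated to stay within the scatter. Compound 3 is expected to give 8 h, between 4 h and 16 h.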

Compound 3, half-life: 16.3 h
The estimate for compound 3 lay 2.0-fold (0.31 log units) below the measured number; the measured number lies above the stated range.
By their numbers in this assay, from the lowest: compounds 2, 1 and 3 (each within the scatter of the next).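

In this assay, putting 5-carboxy-2-methoxyphenyl in place of 3-carboxy-4-hydroxyphenyl gives a 1.5-fold higher number from compound 1 to compound 3 (0.19 log units; within the scatter), so this aromatic position accepts the swap without a step beyond the scatter. Among the compounds shown here, the swap alters the carboxy and the oxygen group together, and the single step cannot divide its size between them. No measurement here bears on the reason for this result.

Which of the two alterations matters, if either does, stays open. So does the outcome with an ethoxy group or an amine in place of the methoxy group.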